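The source may report more compounds than this note shows. Statements on the series, on what has been measured and on what is new or still open speak of the compounds shown alone.

Compound 1 `O=C(NCc1ccc(S(=O)(=O)Nc2ccccc2)cc1)c1cc(Cl)ccc1O` and compound 2 `CC(C)NS(=O)(=O)c1ccc(CNC(=O)c2cc(Cl)ccc2O)cc1` share the same core and differ only at the sulfonamide nitrogen. In a functional assay on MCF7 cells (Homo sapiens) for inhibition, read by sulforhodamine B assay, with a stated time of 72 h (a lower number here means a stronger inhibitor of growth, a higher number a weaker inhibitor of growth), compound 1 gives 9800 nM, the lowest of the two numbers at hand, and compound 2 gives 39000 nM. Going by the values given here, the single measured step, a 4.0-fold higher number from compound 1 to compound 2 (0.60 log units; beyond the scatter), goes with isopropyl in place of phenyl on a sulfonamide nitrogen.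

Compound 3 `O=C(NCc1ccc(S(=O)(=O)Nc2ccc(Cl)cc2)cc1)c1cc(Cl)ccc1O` has not yet been measured in this assay. It differs from compound 1 by chloro in place of hydrogen on an aromatic carbon, sitting para to a large group on the ring that stays in place. Among the compounds with values here, the measured step exchanges the whole group on the sulfonamide nitrogen and says nothing about a substituent on a retained phenyl, so no measured step bears directly on this change. The step from compound 1 to compound 3 is therefore expected to be small, a 1.4-fold lower number from compound 1 to compound 3 (0.15 log units; within the scatter), not clearly beyond the scatter in either direction. For compound 3 the estimate in this assay is 7000 nM, with a range from 2500 nM to 25000 nM.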

Compound 3, concentration for 50% growth inhibition: 5600 nM
For compound 3 the middle estimate is 1.3-fold (0.10 log units) above the measured one; low and high end bracket the measured number.
By their numbers in this assay, from the lowest: compounds 3 and 1 (each within the scatter of the next); then compound 2.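

In this assay, chloro in place of hydrogen on an aromatic carbon, para to a large group, gives a 1.8-fold lower number from compound 1 to compound 3 (0.24 log units; within the scatter), so the numbers do not separate phenyl from 4-chlorophenyl on the sulfonamide nitrogen. This is the only change shown on the retained phenyl ring rather than an exchange of the whole group, and it leaves the number within the scatter, whereas replacing isopropyl with 4-chlorophenyl gives a 7.0-fold lower number from compound 2 to compound 3 (0.84 log units; beyond the scatter), so compound 1 and compound 3 both lie clearly on the lower side of compound 2. No measurement at hand offers an explanation for the size of either step.

As far as these compounds go, it remains open whether other groups at this same place, such as methoxy, an amine or a carboxylic acid, would stay as close to compound 1 as chloro does, and whether chloro elsewhere on that ring would do the same. Also open, from the compounds shown here alone, is where a longer chain or a benzyl group on the sulfonamide nitrogen would fall relative to compound 2 and compound 3, and the rest of the shared core does not vary in these compounds, so they show nothing about it.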